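Ester to Amine: What Solubility to Expect

This account rests on a few compounds, and the source may have more. Where it says the series, first, only, none or still open, it means among the compounds named here.

Compound 1 `COC(=O)c1cccc(-c2cnc(Nc3cccc(F)c3)o2)c1` gives < 1000 nM in a physicochemical assay for solubility, using the shake flask method, measured as kinetic solubility, at pH 7.4 (on this read-out lower numbers stand for lower solubility and higher numbers for higher solubility), a limit of the assay rather than a number.
Compound 2 `COC(=O)c1cccc(-c2cnc(Nc3ccc(F)cc3)o2)c1` gives < 1000 nM in this assay, again a limit.

Compound 2 therefore stands at the limit, with no number of its own; the limit of < 1000 nM in this assay, at which 2 of the 2 values shown sit, covers both measured values. Compound 3 `Nc1cccc(-c2cnc(Nc3ccc(F)cc3)o2)c1` differs from compound 2 by amino in place of methoxycarbonyl on an aromatic carbon. For the measured compounds named here, the only measured step, a step that the two limits leave unreadable from compound 1 to compound 2, is unreadable and so gives no size and no direction for this change. Compound 3 is nonetheless expected to reach 3000 nM, between 600 nM and 15000 nM. This corresponds to an expected step of an at least 3.0-fold higher number from compound 2 to compound 3 (0.47 log units; beyond the scatter) in this assay.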

Compound 3, solubility: 15200 nM
The estimate for compound 3 lay 5.1-fold (0.70 log units) below the measured number; measured number above the stated range.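

At this place, on an aromatic carbon meta to a large group, amino in place of methoxycarbonyl gives an at least 15-fold higher number from compound 2 to compound 3 (1.18 log units; beyond the scatter) in this assay. For the compounds shown here, this is the first step that can be read, and its size is a lower bound. The other compounds stay at a limit of the assay rather than a number: the limit of < 1000 nM in this assay, at which 2 of the 3 values shown sit.

The compounds shown leave open whether another group at this place, such as a carboxylic acid or an acetamide, would give a similar number. They also leave open whether the step would hold with the 3-fluorophenyl of compound 1.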